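The source may hold more compounds than are shown below. What is called first, only, known or untested is meant among the compounds shown, and "the series" means these compounds.

Working notes on the series, read in a functional assay on K562 cells (Homo sapiens) for antiproliferative activity, read by MTT assay, with a stated time of 24 h; a lower number here means a stronger inhibitor, a higher number a weaker inhibitor. Compound 3 `COc1ccc(C(=O)/C=C/c2ccccc2Cl)c2c1C=CC(C)(C)O2` has no number, only a limit: compound 3 stands at > 10000 nM. Compound 1 `COc1ccc(/C=C/C(=O)c2ccc(OC)c3c2OC(C)(C)C=C3)c(F)c1` is also only a limit, at > 10000 nM. Compound 2 `COc1ccc(C(=O)/C=C/c2ccc(N(C)C)cc2)c2c1C=CC(C)(C)O2` gives a true number, 3500 nM. Compound 4 `COc1ccccc1/C=C/C(=O)c1ccc(OC)c2c1OC(C)(C)C=C2` differs from compound 3 by methoxy in place of chloro on an aromatic carbon, ortho to a large group. Among the measured compounds shown here, no measured step makes this exchange. The nearest are an at least 2.8-fold lower number from compound 1 to compound 2 (0.45 log units; beyond the scatter) and an at least 2.8-fold higher number from compound 2 to compound 3 (0.45 log units; beyond the scatter), both tied to the 4-(dimethylamino)phenyl group, while a step that the two limits leave unreadable from compound 1 to compound 3. No step beyond the scatter is therefore expected, and the expected step is a number no higher from compound 3 to compound 4 (the limit leaves the size open). The estimate for compound 4 is 10000 nM, within an expected range of 4000 nM to 25000 nM.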

Compound 4, half-maximal inhibitory concentration: > 10000 nM
Compound 4: only a limit was reported; the forecaster's own chance of this, stated with the estimate: 70%; the middle value lies on the limit itself.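

In this assay compound 4 gives > 10000 nM, which is a limit and not a number. Methoxy in place of chloro on this aromatic carbon therefore cannot be read, and neither can the step between compound 1 and compound 4, as both sides of each pair are limits: the limit of > 10000 nM in this assay, at which 3 of the 4 values shown sit. The one readable step is an at least 2.8-fold higher number from compound 2 to compound 4 (0.45 log units; beyond the scatter), so 2-methoxyphenyl, like 2-chlorophenyl, gives no true number in the compounds shown.

On these data alone, how far compounds 1, 3 and 4 lie apart stays open. Also open, as far as these compounds go, is whether a primary amine on this aromatic carbon would give a true number.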